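A few compounds are considered here, and "the series" means these few. Any claim that something is new, unique, unknown or untested is made for them only; others in the source may bear on it.

Of the compounds shown here, three that share one core have been tested in an ADME assay on microsomes from liver (Homo sapiens) for metabolic stability; on this read-out higher numbers stand for a longer-lived compound and lower numbers for a shorter-lived compound. Compound 1 `COc1cc(OCc2csc(-c3ccc(C(C)(C)O)cc3)n2)c2cc(-c3cn4nc(OC)sc4n3)oc2c1` gives 1.83 h in this assay. Compound 3 `COc1cc(OCc2csc(-c3ccc(C(F)(F)F)cc3)n2)c2cc(-c3cn4nc(OC)sc4n3)oc2c1` reaches the limit of the assay, reported as > 2 h. Compound 2 `COc1cc(OCc2cccc(-c3ccc(C#N)cc3)c2)c2cc(-c3cn4nc(OC)sc4n3)oc2c1` also stands at a limit rather than a number, reported as > 2 h. For the measured compounds named here, the single measured change, an at least 1.0-fold higher number from compound 1 to compound 3 (0.03 log units; that floor lies within the scatter), lies within the scatter. The data also show (the limit of > 2 h in this assay, at which 2 of the 3 values shown sit). Compound 4 `COc1cc(OCc2cccc(-c3cncnc3)c2)c2cc(-c3cn4nc(OC)sc4n3)oc2c1` differs from compound 2 by pyrimidin-5-yl in place of 4-cyanophenyl on an aromatic carbon. Going by the values given here, no measured step touches this part of the molecule. A shift of no more than the scatter, a number no higher from compound 2 to compound 4 (the limit leaves the size open), is therefore expected. Compound 4 is estimated to give 2 h, with a likely range from 1 h to 4 h.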

Compound 4, half-life: 0.117 h
Compound 4: middle estimate off by 17-fold (1.23 log units), on the high side; measured number outside the range, below it.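

At this position, on an aromatic carbon of the six-membered carbon ring, the group strongly affects the result in this assay: pyrimidin-5-yl in place of 4-cyanophenyl gives an at least 17-fold lower number from compound 2 to compound 4 (1.23 log units; beyond the scatter). Compound 2 is given as > 2 h, which is a limit of the assay and not a number. The earlier step between compound 1 and compound 3 stayed within the scatter, so this is the first change shown that goes beyond it. From the compounds shown here alone, whether the ring nitrogens or the loss of the nitrile matters more stays open. A plain phenyl or a pyridin-3-yl group here would help separate the two.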